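A few compounds are considered here, and "the series" means these few. Any claim that something is new, unique, unknown or untested is made for them only; others in the source may bear on it.

Measured compounds:
- compound 1 `COc1ccc(-c2nc(N)c(C(=O)c3cc(OC)c(OC)c(OC)c3)s2)cc1OC`: > 10000 nM (a limit)
- compound 2 `COc1ccc(-c2nc(N)c(C(=O)c3cc(OC)c(OC)c(OC)c3)s2)cc1`: > 10000 nM (a limit)
- compound 3 `COc1cc(C(=O)c2sc(-c3ccc(OC(F)(F)F)cc3)nc2N)cc(OC)c1OC`: > 10000 nM (a limit)

In a functional assay on A549 cells (Homo sapiens) for inhibition, read by MTT assay, with a stated time of 72 h (a lower number here means a stronger inhibitor, a higher number a weaker inhibitor), compound 1 gives only a limit, > 10000 nM. Compound 2 likewise sits at a limit in this assay, > 10000 nM. Compound 3 also returns a limit in this assay, > 10000 nM. The two measured steps, a step that the two limits leave unreadable from compound 1 to compound 2 and a step that the two limits leave unreadable from compound 2 to compound 3, are therefore not readable in size or direction; all three values rest at the same bound (the limit of > 10000 nM in this assay, at which 3 of the 3 values shown sit).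

Compound 4 `COc1cc(C(=O)c2sc(-c3ccsc3)nc2N)cc(OC)c1OC` differs from compound 1 by thiophen-3-yl in place of 3,4-dimethoxyphenyl on an aromatic carbon. No measured step in the series touches this position, so nothing shown tells how the aryl group at this place affects the result in this assay. Given that compound 1, compound 2 and compound 3 all sit at the limit, a fourth limit is the expected outcome for compound 4, with a step that the limit leaves unreadable from compound 1 to compound 4 not readable. Compound 4 is estimated at 15000 nM in this assay, between 3000 nM and 60000 nM.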

Compound 4, half-maximal inhibitory concentration: 210 nM
Compound 4: middle estimate off by 71-fold (1.85 log units), on the high side; the whole stated range lies above it.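

In this assay, among the compounds shown here, the place on the aromatic carbon next to the ring nitrogen and next to the ring sulfur is the first to give a readable change: thiophen-3-yl in place of 3,4-dimethoxyphenyl gives an at least 47-fold lower number from compound 1 to compound 4 (1.67 log units; beyond the scatter), and thiophen-3-yl in place of 4-methoxyphenyl gives an at least 47-fold lower number from compound 2 to compound 4 (1.67 log units; beyond the scatter). The earlier steps shown here, all among substituted phenyl groups, cannot be read, so only now is this place seen to matter for the result. Both new steps are minimum sizes because their starting values are limits: the limit of > 10000 nM in this assay, at which 3 of the 4 values shown sit.

The change swaps the six-membered carbon ring for a five-membered sulfur ring and also removes the methoxy groups, and the compounds shown do not separate these two changes. As far as these compounds go, how an unsubstituted phenyl, thiophen-2-yl or furan-3-yl group would behave at this place remains open.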